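Acetamidomethyl to amino(carboxy)methyl on a chromane side chain

A few compounds are considered here, and "the series" means these few. Any claim that something is new, unique, unknown or untested is made for them only; others in the source may bear on it.

Measured so far in an ADME assay on SH-SY5Y cells (Homo sapiens) for cytotoxicity, read by MTT assay, with a stated time of 24 h, tested at 100 uM; on this read-out lower numbers stand for a stronger effect and higher numbers for a weaker effect at the one concentration tested:
compound 1 `COc1cc2c(cc1O)CCC(C)(CC(N)=O)O2` gives 51.4%
compound 2 `COc1cc2c(cc1O)CCC(C)(CCNC(C)=O)O2` gives 57.9%

Going by the values given here, compound 2 holds the higher of the two numbers, but the only step between the two is a number 6.5 percentage points higher from compound 1 to compound 2 (within the scatter), so the two are not distinguishable by this assay. Compound 3 `COc1cc2c(cc1O)CCC(C)(CC(N)C(=O)O)O2` is not yet measured. It differs from compound 2 by amino(carboxy)methyl in place of acetamidomethyl on a saturated chain carbon bound to a saturated ring carbon. Among the compounds with values here, the only measured step that touches this same position is the one from compound 1 to compound 2, which was a number 6.5 percentage points higher from compound 1 to compound 2 (within the scatter); a change at the same saturated chain carbon left the read-out where it was. On that basis, no step beyond the scatter is expected in this assay for compound 3. The expected step is a number 1.9 percentage points lower from compound 2 to compound 3 (within the scatter). Compound 3 is estimated at 56%, within a range from 40% to 72%.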

Compound 3, a percentage reported as activity, at one concentration (the size of the read-out at that concentration, not a potency): 60.1%
Beside the measured number, compound 3's estimate is 4.1 percentage points below it; low and high end bracket the measured number.
By their numbers in this assay, from the lowest: compounds 1, 2 and 3 (each within the scatter of the next).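

In this assay, amino(carboxy)methyl in place of acetamidomethyl on a saturated chain carbon bound to a saturated ring carbon gives a number 2.2 percentage points higher from compound 2 to compound 3 (within the scatter) and, in place of carbamoyl at the same carbon, gives a number 8.7 percentage points higher from compound 1 to compound 3 (within the scatter) so all three groups read alike here. The earlier pair showed this only for two neutral amide groups, whereas the group now entering carries a free amino group and a carboxy group on the chain, and the read-out still cannot tell it from either amide. No measured evidence is available to explain this result.

Going by these compounds, whether a chain ending in a carboxylic acid alone, or in an amine alone, would read the same remains open. So does whether a longer chain or a phenyl ring at this carbon would produce a step beyond the scatter.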